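Trimethylphenyl for trifluorophenyl urea on a pyridinyl core

This account rests on a few compounds, and the source may have more. Where it says the series, first, only, none or still open, it means among the compounds named here.

Measured compounds:
Compound 1 `O=C(Nc1c(F)cc(F)cc1F)N(Cc1ccc(-c2ccsc2)cc1)C1CCCCCC1` gives > 1 mg/kg in a functional assay on a cell-free system (plasma) with sterol O-acyltransferase, Soat (Rattus norvegicus) as the target; a higher number here means that more compound is needed for the effect, a lower number that less compound is needed.
Compound 2 `Cc1cc(C)c(NC(=O)N(Cc2ccc(-c3ccsc3)cc2)C2CCCCCC2)c(C)c1` gives 0.51 mg/kg in this assay.
Compound 3 `O=C(Nc1c(F)cc(F)cc1F)N(Cc1ccc(-c2ccccn2)cc1)C1CCCCCC1` gives > 1 mg/kg in this assay.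

The value of compound 1 is a limit of the assay and not a number. The value of compound 3 is likewise a limit. Compound 2 is the only one of the three with a numbered result.

Compound 1 and compound 2 differ in one place, (2,4,6-trimethylphenyl in place of 2,4,6-trifluorophenyl on an amide-type nitrogen), and this change made the step of an at least 1.9-fold lower number from compound 1 to compound 2 (0.29 log units; that floor lies within the scatter). Compound 1 and compound 3 differ in their cores, (pyridin-2-yl in place of thiophen-3-yl on an aromatic carbon), and that step reads a step that the two limits leave unreadable from compound 1 to compound 3, since both compound 1 and compound 3 sit at the limit of > 1 mg/kg in this assay, at which 2 of the 3 values shown sit.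

Compound 4 `Cc1cc(C)c(NC(=O)N(Cc2ccc(-c3ccccn3)cc2)C2CCCCCC2)c(C)c1` has not yet been measured in this assay. For the measured compounds named here, it differs from compound 3 by 2,4,6-trimethylphenyl in place of 2,4,6-trifluorophenyl on an amide-type nitrogen, which is the same change, in the same place, as the one from compound 1 to compound 2. Going by the values given here, the step it made there is the only guide, and that step is itself only a floor.

Compound 4 is therefore expected to give about 0.8 mg/kg, somewhere between 0.3 mg/kg and 2.5 mg/kg. The expected step is an at least 1.2-fold lower number from compound 3 to compound 4 (0.09 log units; that floor lies within the scatter), resting on compound 1 and compound 2 and their measured step of an at least 1.9-fold lower number from compound 1 to compound 2 (0.29 log units; that floor lies within the scatter), with the caveat that compound 3 itself is known only as a limit.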

Compound 4, dose for half-maximal effect: > 1 mg/kg
Compound 4 ended at the assay's limit (the forecaster's own chance of this, stated with the estimate: 40%); at least 1.2-fold (0.09 log units) between middle value and limit.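

In this assay compound 4 gives > 1 mg/kg, which is a limit of the assay and not a number. For the compounds shown here, the step from compound 3 to compound 4 cannot be read, because both compounds end at the same limit: the limit of > 1 mg/kg in this assay, at which 3 of the 4 values shown sit. The one readable step is an at least 1.9-fold higher number from compound 2 to compound 4 (0.29 log units; that floor lies within the scatter), for pyridin-2-yl in place of thiophen-3-yl with the 2,4,6-trimethylphenyl group kept, so the change to 2,4,6-trimethylphenyl that gave a numbered result with thiophen-3-yl gave none with pyridin-2-yl, yet this floor lies within the scatter, and the data show neither that the change carries over to the second core nor that it fails to.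

The compounds shown leave open how far compound 3 and compound 4 actually lie from the limit, and so whether the change from 2,4,6-trifluorophenyl to 2,4,6-trimethylphenyl has any effect at all with pyridin-2-yl in place. Also open, on these data alone, is whether a plain phenyl group or a dimethylamino group, standing where thiophen-3-yl and pyridin-2-yl stand, would give a numbered result alongside 2,4,6-trimethylphenyl.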